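Anilide in Place of Benzylamide on an Inactive Core

The compounds below may be only part of what the source reports. "The series", "measured", "known", "first", "only" and "open" are said of these compounds alone.

Compound 2 `C=CC1=C(C(=O)NCc2ccc(Cl)cc2)C(c2ccc(F)cc2)OC1` carries a benzylamide on the shared core. In a functional assay on A549 cells (Homo sapiens) for cytotoxicity, read by MTT assay, with a stated time of 24 h (a lower number here means a stronger inhibitor, a higher number a weaker inhibitor), compound 2 reaches only a limit, > 100000 nM. Its neighbour compound 1 `C=CC1=C(C(=O)NCCC)C(c2ccc(F)cc2)OC1` likewise gives only a limit in this assay, namely > 100000 nM. The step between them, a step that the two limits leave unreadable from compound 1 to compound 2, is therefore unreadable; both values sit at the limit of > 100000 nM in this assay, at which 2 of the 2 values shown sit. Compound 3 `C=CC1=C(C(=O)Nc2ccccc2OC)C(c2ccc(F)cc2)OC1` differs from compound 2 in one place: 2-methoxyphenyl in place of 4-chlorobenzyl on an amide-type nitrogen. For the measured compounds named here, no measured step resolves a number on either side of this change, and the expectation rests on the two limits alone; no direction can be drawn from them. Compound 3 is therefore expected to stay at or near the same limit in this assay, the estimated step being a step that the limit leaves unreadable from compound 2 to compound 3. The estimate for compound 3 is 150000 nM, with a range from 50000 nM to 500000 nM.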

Compound 3, half-maximal inhibitory concentration: > 100000 nM
Compound 3 gave a limit, no number (the forecaster's own chance of this, stated with the estimate: 85%); the middle value lies beyond the limit too.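

Compound 3 gives only a limit, as do compound 1 and compound 2, so no step among these three compounds can be read: the limit of > 100000 nM in this assay, at which 3 of the 3 values shown sit.

The compounds shown leave open whether any group on the amide-type nitrogen of the shared core would give a measurable number in this assay.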